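A Halogen Swap on a Scaffold That Gave No Number

The source may hold more compounds than are shown below. What is called first, only, known or untested is meant among the compounds shown, and "the series" means these compounds.

Compound 2 `O=C(c1oc(C(F)(F)F)nc1-c1ccc(F)cc1)N1CCN(c2cccc(Cl)c2)CC1` is one of two close relatives for which the screen returned no concentration. In a functional assay on HL-60 cells (Homo sapiens) for inhibition, read by MTT assay, with a stated time of 72 h (on this read-out higher numbers stand for weaker inhibition and lower numbers for stronger inhibition), compound 2 is recorded as "not active" (no number reported), a statement rather than a measured number. Compound 1 `COc1cccc(N2CCN(C(=O)c3oc(C(F)(F)F)nc3-c3ccc(F)cc3)CC2)c1` shares the trifluoromethyl group of compound 2, and in this assay compound 1 is likewise recorded as "not active" (no number reported). Among the measured compounds shown here, compound 3 `CCc1nc(-c2ccc(F)cc2)c(C(=O)N2CCN(c3cccc(Cl)c3)CC2)o1` carries an ethyl group where compound 1 and compound 2 carry trifluoromethyl, and in this assay compound 3 gives 169 nM, the only number in the set. Compound 4 `O=C(c1oc(C(F)(F)F)nc1-c1cccc(Cl)c1)N1CCN(c2cccc(Cl)c2)CC1` has not been measured. It differs from compound 2 in a single place: 3-chlorophenyl in place of 4-fluorophenyl on an aromatic carbon. The trifluoromethyl group of compound 2 is kept in compound 4. For the measured compounds named here, both compounds that carry that group, compound 1 and compound 2, were reported without a number, and no measured pair shows what this one change does. The author therefore expects compound 4 to remain at the weak end of this assay, with a step beyond the scatter toward stronger inhibition unlikely and a report of no number quite possible. Compound 4 is estimated at 20000 nM, within a range from 3000 nM to 100000 nM.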

Compound 4, half-maximal inhibitory concentration: "not active" (no number reported)
Compound 4 has no reported number here; there is nothing to compare the estimate with.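

Among the compounds shown here, compound 2 and compound 4 both stand without a number in this assay, and no step between them can be read. The compounds shown leave open what 3-chlorophenyl in place of 4-fluorophenyl does where the trifluoromethyl group is absent. No measurement shown here bears on this result.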